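This account rests on a few compounds, and the source may have more. Where it says the series, first, only, none or still open, it means among the compounds named here.

Measured so far:
compound 1, `COc1cc(-c2cc(C(=O)O)c3ccccc3n2)ccc1OCC(=O)Nc1ccccc1F` — 161000 nM
compound 2, `COc1cc(-c2cc(C(=O)O)c3ccccc3n2)ccc1OCC(=O)Nc1cccc(F)c1` — 148000 nM

Both compounds were tested in an ADME assay on HaCaT cells (Homo sapiens) for inhibition; a lower number here means a stronger inhibitor, a higher number a weaker inhibitor. Compound 1 gives 161000 nM and compound 2 gives 148000 nM. Going by the values given here, the single step between them, a 1.1-fold lower number from compound 1 to compound 2 (0.04 log units; within the scatter), lies within the scatter, so on these two numbers compound 2 and compound 1 cannot be told apart; neither stands out.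

Compound 3, `COc1cc(-c2cc(C(=O)O)c3ccccc3n2)ccc1OCC(=O)Nc1ccc(C(F)(F)F)cc1`, has not yet been measured. It differs from compound 2 in one place: 4-(trifluoromethyl)phenyl in place of 3-fluorophenyl on an amide-type nitrogen. Among the compounds with values here, the only measured step, a 1.1-fold lower number from compound 1 to compound 2 (0.04 log units; within the scatter), concerns a different change, the fluorine moving from one position of the phenyl ring to another, and it produced nothing beyond the scatter. Within the data shown here, no measured step shows a trifluoromethyl replacing a fluorine, nor a substituent at the position named in the entering group, so the data give no direct guide to the size or direction of this step. As far as these compounds go, the expectation is therefore for no step beyond the scatter, a 1.1-fold lower number from compound 2 to compound 3 (0.06 log units; within the scatter), with a wide range because the change itself is untested. Compound 3 is estimated at 130000 nM, expected to fall between 55000 nM and 310000 nM.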

Compound 3, half-maximal inhibitory concentration: 150000 nM
Beside the measured number, compound 3's estimate is 1.2-fold (0.06 log units) below it; the range from low to high includes it.
By their numbers in this assay, from the lowest: compounds 2, 3 and 1 (each within the scatter of the next).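

In this assay, the 4-(trifluoromethyl)phenyl group on the amide-type nitrogen, in place of 3-fluorophenyl, gives a 1.0-fold higher number from compound 2 to compound 3 (0.01 log units; within the scatter). Set against the 2-fluorophenyl group, it gives a 1.1-fold lower number from compound 1 to compound 3 (0.03 log units; within the scatter). The earlier pair showed only that a single fluorine could sit at a different place on the phenyl ring without a readable difference; these steps extend that to a different substituent with more heavy atoms, and compound 1, compound 2 and compound 3 cannot be told apart in this assay.

Still open, as far as these compounds go, is whether a phenyl ring carrying an amine or a carboxylic acid, or a longer chain on the amide-type nitrogen in place of the phenyl ring, would move the number beyond the scatter. Nothing available on these compounds accounts for how closely their numbers agree.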